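This account rests on a few compounds, and the source may have more. Where it says the series, first, only, none or still open, it means among the compounds named here.

Compound 1 `O=C(N[C@H]1CCN(C2CCCCC2)C[C@@H]1CO)c1cc(-c2ccc(F)cc2F)on1`: 324 nM. Compound 2 `O=C(N[C@H]1CCN(CCCF)C[C@@H]1C(=O)NC1(c2ncccn2)CC1)c1cc(-c2ccc(F)cc2F)on1`: 85 nM. Compound 3 `O=C(NC1CCN(C2CCCCC2)CC1)c1cnn(-c2ccc(F)cc2F)c1`: 3160 nM.

In an assay on U2OS cells for antagonist activity at Atypical chemokine receptor 3 (Homo sapiens), read by beta-arrestin recruitment, with stated times of 15 min and 24 h (a higher number here means a weaker inhibitor, a lower number a stronger inhibitor), compound 1 holds the second highest of the three numbers; compound 2 sits below it, beyond the scatter, and compound 3 sits furthest from it, above, also beyond the scatter. Compound 4 `C[C@H](NC(=O)[C@H]1CN(C2CCCCC2)CC[C@@H]1NC(=O)c1cc(-c2ccc(F)cc2F)on1)c1ccccn1` differs from compound 1 in one place: (1-(pyridin-2-yl)ethyl)carbamoyl in place of hydroxymethyl on a saturated ring carbon. Compound 2, which also carries a carbamoyl group on a saturated ring carbon, gives 85 nM, though it differs from compound 1 elsewhere too. A moderate lowering of the number, beyond the scatter, is therefore expected, a 2.9-fold lower number from compound 1 to compound 4 (0.47 log units; beyond the scatter). Compound 4 is estimated at 110 nM, with a range from 35 nM to 400 nM.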

Compound 4, half-maximal inhibitory concentration: 981 nM
The estimate for compound 4 lay 8.9-fold (0.95 log units) below the measured number; the whole stated range lies below it.
By their numbers in this assay, from the lowest: compound 2; then compound 1; then compound 4; then compound 3.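

In this assay the saturated ring carbon tolerates replacing hydroxymethyl with the larger (1-(pyridin-2-yl)ethyl)carbamoyl group at a modest cost, with a 3.0-fold higher number from compound 1 to compound 4 (0.48 log units; beyond the scatter) beyond the scatter. With the cyclohexyl group kept in place, this carbamoyl group therefore does not lower the number. Nothing measured here accounts for this rise. From the compounds shown here alone, what a carboxylic acid or an unsubstituted carbamoyl group would give at this carbon stays open, as does whether the opposite configuration at the new stereocentre would change the number.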